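A few compounds are considered here, and "the series" means these few. Any claim that something is new, unique, unknown or untested is made for them only; others in the source may bear on it.

Series values in a functional assay on HepG2 cells (Homo sapiens) for cytotoxicity, read by MTT assay, with a stated time of 24 h; on this read-out higher numbers stand for weaker inhibition and lower numbers for stronger inhibition:
- compound 1 `O=C1/C(=C/c2ccncc2)CN(S(=O)(=O)c2ccccc2)C/C1=C\c1ccccc1F`: 5800 nM
- compound 2 `O=C1/C(=C/c2ccncc2)CN(S(=O)(=O)c2ccccc2)C/C1=C\c1ccccc1C(F)(F)F`: 7020 nM
- compound 3 `O=C1/C(=C/c2ccncc2)CN(S(=O)(=O)c2ccc(C(F)(F)F)cc2)C/C1=C\c1ccccc1C(F)(F)F`: not yet measured

Among the compounds with values here, only two numbers are available so far. Compound 2 gives 7020 nM and sits within the scatter of compound 1, so the two are not separated.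

The next step adds to compound 2 on the phenyl: trifluoromethyl in place of hydrogen on an aromatic carbon. In words, this is trifluoromethyl in place of hydrogen on an aromatic carbon, phenyl to 4-(trifluoromethyl)phenyl.

Within the data shown here, one measured step bears on this, and only loosely: a 1.2-fold higher number from compound 1 to compound 2 (0.08 log units; within the scatter). That step also brings in a trifluoromethyl, but it replaces fluoro on the other aromatic ring. Among the measured compounds shown here, no measured pair shows a change at the new place, so the series offers no direct guide there. On this thin evidence, no step beyond the scatter is expected in this assay, and no direction is favoured, although the uncertainty is wide.

The estimated step is a 1.1-fold lower number from compound 2 to compound 3 (0.03 log units; within the scatter).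

The expected value for compound 3 is 6500 nM, with an estimated range of 2800 nM to 14000 nM.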

Compound 3, half-maximal inhibitory concentration: 3240 nM
The estimate for compound 3 lay 2.0-fold (0.30 log units) above the measured number; the range from low to high includes it.
By their numbers in this assay, from the lowest: compounds 3, 1 and 2 (each within the scatter of the next, the first and the last beyond it).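

In this assay, the change from phenyl to 4-(trifluoromethyl)phenyl gives a 2.2-fold lower number from compound 2 to compound 3 (0.34 log units; beyond the scatter), so this position responds to substitution, although the step is modest. The earlier change, with a 1.2-fold higher number from compound 1 to compound 2 (0.08 log units; within the scatter), brought in trifluoromethyl on the other aromatic ring in place of fluoro and did not separate its pair. The same group therefore has a readable effect here in the direction of stronger inhibition, but this rests on a single pair, and nothing available accounts for the shift.

The compounds shown leave open whether the step belongs to trifluoromethyl itself or would also appear with a fluoro, a methoxy, an amine or a carboxylic acid at the same place. They also leave open whether 4-(trifluoromethyl)phenyl gives a similar step when the other aromatic ring carries fluoro, as in compound 1, rather than trifluoromethyl, as in compound 2.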